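Matched aryl swaps on a pyridone-amide series

This account rests on a few compounds, and the source may have more. Where it says the series, first, only, none or still open, it means among the compounds named here.

A small set of amide-linked pyridone compounds was tested in a functional assay on HT-29 cells (Homo sapiens) for antiproliferative activity, read by MTT assay, with a stated time of 72 h; a higher number here means a weaker inhibitor, a lower number a stronger inhibitor. Compound 1 `Cn1ccc2c(Oc3ccc(NC(=O)c4cc5cccnc5n(-c5ccc(Br)cc5F)c4=O)cc3)ccnc21` gives 2580 nM. Compound 2 `Cn1ccc2c(Oc3ccc(NC(=O)c4cc5cccnc5n(-c5ccc(C(F)(F)F)cc5Cl)c4=O)cc3)ccnc21` gives 6050 nM, so that there is a 2.3-fold higher number from compound 1 to compound 2 (0.37 log units; beyond the scatter). The difference between these two is 2-chloro-4-(trifluoromethyl)phenyl in place of 4-bromo-2-fluorophenyl on an aromatic nitrogen. Compound 3 `Cn1ccc2c(Oc3ccc(NC(=O)c4cc5cccnc5n(-c5ccc(Br)cc5F)c4=O)cc3F)ccnc21` gives 3290 nM, which is a 1.3-fold higher number from compound 1 to compound 3 (0.11 log units; within the scatter); the change from compound 1 to compound 3 is fluoro in place of hydrogen on an aromatic carbon, and this is also how the core of compound 3 differs from the core of compound 1.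

Compound 4 `Cn1ccc2c(Oc3ccc(NC(=O)c4cc5cccnc5n(-c5ccc(C(F)(F)F)cc5Cl)c4=O)cc3F)ccnc21` has not yet been tested in this assay. It differs from compound 3 by 2-chloro-4-(trifluoromethyl)phenyl in place of 4-bromo-2-fluorophenyl on an aromatic nitrogen. The place of this change is described in the same words as for the step from compound 1 to compound 2, so it is the same change, made on the fluorinated core rather than the unsubstituted one.

The expectation for compound 4 therefore rests on compound 3 and its value 3290 nM, shifted by the size of the earlier step, and it is expected to be a 2.3-fold higher number from compound 3 to compound 4 (0.36 log units; beyond the scatter). On that basis compound 4 is estimated at 7500 nM, with a range from 3500 nM to 16000 nM expected to cover most repeats.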

Compound 4, half-maximal inhibitory concentration: 5830 nM
Beside the measured number, compound 4's estimate is 1.3-fold (0.11 log units) above it, and the stated range covers the measured number.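

In this assay, 2-chloro-4-(trifluoromethyl)phenyl in place of 4-bromo-2-fluorophenyl on the fluorinated core gives a 1.8-fold higher number from compound 3 to compound 4 (0.25 log units; within the scatter), and this step agrees with its counterpart on the core of compound 1: the same change on two cores in this assay, a 2.3-fold higher number (0.37 log units; beyond the scatter) from compound 1 to compound 2 and a 1.8-fold higher number (0.25 log units; within the scatter) from compound 3 to compound 4, 1.3-fold (0.12 log units) apart, within the scatter of two such steps. The fluoro in place of hydrogen on an aromatic carbon, read in the presence of the 2-chloro-4-(trifluoromethyl)phenyl group, gives a 1.0-fold lower number from compound 2 to compound 4 (0.02 log units; within the scatter), and it also agrees with its earlier counterpart: the same change on two cores in this assay, a 1.3-fold higher number (0.11 log units; within the scatter) from compound 1 to compound 3 and a 1.0-fold lower number (0.02 log units; within the scatter) from compound 2 to compound 4, 1.3-fold (0.12 log units) apart, within the scatter of two such steps. Within these four compounds, each change therefore carries from one core to the other without a detectable difference, but this rests on only two cores and two pairs per change, the aryl step is beyond the scatter on one core and within it on the other, and the data do not show that either change would transfer in the same way to any further core, nor why the steps agree.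

The compounds shown leave open how other groups on the aromatic nitrogen, such as an unsubstituted phenyl or a phenyl carrying a methoxy or an amine, would behave on these two cores. They also leave open whether chloro or methyl in place of the added fluoro would carry across the two aryl groups in the same way.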